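The compounds below may be only part of what the source reports. "The series", "measured", "known", "first", "only" and "open" are said of these compounds alone.

Measured so far in a functional assay on MOLT-4 cells (Homo sapiens) for inhibition, read by sulforhodamine B assay, with a stated time of 48 h, tested at 1 uM; a higher number here means a weaker effect of the compound at the concentration tested, a lower number a stronger effect:
- compound 1, `O=C(Nc1cccc(-n2cc(-c3ccncc3)c(-c3cc(O)cc(Cl)c3)n2)c1)Nc1ccc(Cl)c(C(F)(F)F)c1`, giving 52%
- compound 2, `O=C(Nc1cccc(-n2cc(-c3ccncc3)c(-c3cc(O)cc(Cl)c3)n2)c1)Nc1ccc(Cl)c(Cl)c1`, giving 84%
- compound 3, `COc1cc(Cl)cc(-c2nn(-c3cccc(NC(=O)Nc4cc(C(F)(F)F)cc(C(F)(F)F)c4)c3)cc2-c2ccncc2)c1`, giving 10%

Compound 3 stands lowest of the three numbers in this assay, and since a lower number means a stronger effect, it is the strongest of the set; the nearest is compound 1, the furthest compound 2, both gaps beyond the scatter.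

Compound 4, `COc1cc(Cl)cc(-c2nn(-c3cccc(NC(=O)Nc4cccc(C(F)(F)F)c4)c3)cc2-c2ccncc2)c1`, is not yet measured. The change from compound 3 is hydrogen in place of trifluoromethyl on an aromatic carbon: one of the two trifluoromethyl groups on the terminal phenyl of the urea is removed, the other stays.

Among the measured compounds shown here, one measured step bears on changes at this phenyl: a number 32 percentage points higher from compound 1 to compound 2 (beyond the scatter), where a chloro replaced a trifluoromethyl and the number rose sharply, meaning a weaker effect. For the measured compounds named here, no step shows a trifluoromethyl replaced by hydrogen, so the comparison is indirect, but both point the same way: taking a trifluoromethyl away from this ring is expected to raise the number. The step to compound 4 is therefore expected to be large and upward, a number 35 percentage points higher from compound 3 to compound 4 (beyond the scatter), though probably not reaching the level of compound 2.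

For compound 4 the estimate is 45%, with a range from 20% to 75%.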

Compound 4, a percentage reported as activity, at one concentration (the size of the read-out at that concentration, not a potency): 55%
For compound 4 the middle estimate is 10 percentage points below the measured one; the measured number falls inside the stated range.
By their numbers in this assay, from the lowest: compound 3; then compounds 1 and 4 (each within the scatter of the next); then compound 2.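

In this assay, the trifluoromethyl that leaves carries a large share of the effect seen with compound 3: with hydrogen in its place and the other trifluoromethyl retained, the result is a number 45 percentage points higher from compound 3 to compound 4 (beyond the scatter). Among the compounds shown here, this is the first step that removes a trifluoromethyl from this six-membered aromatic ring outright, rather than exchanging it for another substituent; the earlier step, with chloro in place of trifluoromethyl, was a number 32 percentage points higher from compound 1 to compound 2 (beyond the scatter), and the two steps agree in direction, both beyond the scatter, though they sit on different parent compounds. No measurement is available that explains why this place responds so strongly to the change.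

The compounds shown leave open whether a different group at this place, such as a nitrile or an amine, would keep the number close to that of compound 3 at 10% or would behave like hydrogen. Also open, going by these compounds, is how far the number would move if the remaining trifluoromethyl of compound 4 were replaced by hydrogen as well.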